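The source may report more compounds than this note shows. Statements on the series, on what has been measured and on what is new or still open speak of the compounds shown alone.

Measured so far in the cytotoxicity assay:
- compound 1 `Nc1nc(NC2CC2)c2ncn(/C=C3/CC3(CO)CO)c2n1`: 71500 nM
- compound 2 `CC(C)CSc1nc(N)nc2c1ncn2/C=C1/CC1(CO)CO`: > 20000 nM, which is a limit of the assay and not a number
- compound 3 `CCCOc1nc(N)nc2c1ncn2/C=C1/CC1(CO)CO`: > 20000 nM, likewise a limit of the assay and not a number

For the measured compounds named here, in an ADME assay on BCBL1 cells (Homo sapiens) for cytotoxicity, with a stated time of 7 days (a lower number here means that less compound is tolerated, a higher number that more compound is tolerated), compound 1 is the only compound with a measured number, 71500 nM. Compound 2 stands at the limit of > 20000 nM in this assay, at which 2 of the 3 values shown sit, so its position is known only as a limit. For the same reason the steps a step that the limit leaves unreadable from compound 1 to compound 2 and a step that the limit leaves unreadable from compound 1 to compound 3 cannot be sized, and neither can a step that the two limits leave unreadable from compound 2 to compound 3.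

Compound 4 `CC(C)Nc1nc(N)nc2c1ncn2/C=C1/CC1(CO)CO` differs from compound 2 by isopropylamino in place of isobutylsulfanyl on an aromatic carbon. Going by the values given here, no measured step bears readably on this change. The nearest guide is compound 1, whose cyclopropylamino group is, like isopropylamino, an amino substituent at that position, and which gives 71500 nM. The step that the limit leaves unreadable from compound 2 to compound 4 is therefore expected to leave compound 4 in the same tolerated region, plausibly again beyond the assay limit. Compound 4 is estimated at 60000 nM, with a range from 20000 nM to 150000 nM.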

Compound 4, half-maximal cytotoxic concentration: > 20000 nM
Compound 4: no number, only a limit; the forecaster's own chance of this, stated with the estimate: 45%; the middle value lies beyond the limit too.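

In this assay compound 4 gives > 20000 nM, which is a limit of the assay and not a number. For the compounds shown here, no step between compound 4 and compound 1, compound 2 or compound 3 can be read. The compounds shown leave open how compound 2, compound 3 and compound 4 rank against each other and against compound 1.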